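This account rests on a few compounds, and the source may have more. Where it says the series, first, only, none or still open, it means among the compounds named here.

In a functional assay on U-251 cells (Homo sapiens) for antiproliferative activity, read by MTT assay, with a stated time of 24 h (on this read-out lower numbers stand for stronger inhibition and higher numbers for weaker inhibition), compound 1 `COc1cc(OC)c(-c2coc3cc(OCc4ccc(C#N)cc4)ccc3c2=O)cc1OC` gives 6180 nM and compound 2 `COc1cc(OC)c(-c2coc3cc(OCc4ccc(Cl)cc4)ccc3c2=O)cc1OC` gives 470 nM, so compound 2 holds the lower of the two numbers. Compound 3 `COc1cc(OC)c(-c2coc3cc(OCc4cccc(C(F)(F)F)c4)ccc3c2=O)cc1OC` keeps the shared core and differs from compound 2 in one place: 3-(trifluoromethyl)phenyl in place of 4-chlorophenyl on a saturated chain carbon bound to an oxygen on an aromatic ring. In other words, 3-(trifluoromethyl)benzyl stands where 4-chlorobenzyl stood. For the measured compounds named here, only one measured step bears on this change, a 13-fold lower number from compound 1 to compound 2 (1.12 log units; beyond the scatter), which was large and shows that a swap of one group on this aromatic ring can move the number well beyond the scatter. Going by the values given here, no measured compound carries a trifluoromethyl group, so that step gives a scale but no firm direction. With compound 2 at the low end of the range seen so far, a moderately higher number is expected. The expected change is a 1.9-fold higher number from compound 2 to compound 3 (0.28 log units; within the scatter), smaller than the measured step. For compound 3 the estimated value is 900 nM, within an expected range of 250 nM to 3500 nM.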

Compound 3, half-maximal inhibitory concentration: > 10000 nM
Compound 3: only a limit was reported (the forecaster's own chance of this, stated with the estimate: 3%); at least 11-fold (1.04 log units) between middle value and limit.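

In this assay compound 3 carries only a limit and not a number: the limit of > 10000 nM in this assay, at which 1 of the 3 values shown sits. Even so, 3-(trifluoromethyl)phenyl in place of 4-chlorophenyl gives an at least 21-fold higher number from compound 2 to compound 3 (1.32 log units; beyond the scatter), so compound 2 now stands apart from both other compounds by steps beyond the scatter, and this position can respond sharply to the group it carries. Set against the nitrile-bearing group, the same position gives an at least 1.6-fold higher number from compound 1 to compound 3 (0.20 log units; that floor lies within the scatter), and with that floor inside the scatter the order of these two compounds stays unsettled.

The compounds shown leave open whether the step from 4-chlorobenzyl to 3-(trifluoromethyl)benzyl follows the change of group or its change of place on the ring, as the two change together. On these data alone, how a 4-methoxyphenyl or 4-aminophenyl group would stand here also remains open.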